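This account rests on a few compounds, and the source may have more. Where it says the series, first, only, none or still open, it means among the compounds named here.

Among the measured compounds shown here, compound 3 `COc1cccc(CNCCCNc2ccnc3cc(Oc4ccc(C(C)(C)C)cc4)ccc23)c1O` gives 14500 nM in a physicochemical assay for solubility, with a stated time of 18 h, at pH 7.4 (on this read-out lower numbers stand for lower solubility and higher numbers for higher solubility), the second highest of the three numbers so far: compound 1 `COc1cccc(CNCCCNc2ccnc3cc(-c4ccc(C(C)(C)C)cc4)ccc23)c1O` gives 32000 nM and compound 2 `COc1cccc(CNCCCNc2ccnc3cc(Cc4ccc(F)cc4)ccc23)c1O` gives 4200 nM. The measured steps run a 2.2-fold lower number from compound 1 to compound 3 (0.34 log units; beyond the scatter), a 7.6-fold lower number from compound 1 to compound 2 (0.88 log units; beyond the scatter) and a 3.5-fold higher number from compound 2 to compound 3 (0.54 log units; beyond the scatter). Compound 4 `COc1cccc(CNCCCNc2ccnc3cc(-c4cccc5ccccc45)ccc23)c1O` differs from compound 3 by naphthalen-1-yl in place of 4-(tert-butyl)phenoxy on an aromatic carbon. The step that bears on it most is a 2.2-fold lower number from compound 1 to compound 3 (0.34 log units; beyond the scatter): compound 4 again carries a directly attached aryl group, as compound 1 does, whereas the lowest number of the set belongs to compound 2. For the measured compounds named here, no measured step involves naphthalen-1-yl, so the size remains uncertain; a modest change in either direction, or none beyond the scatter, is expected. Compound 4 is expected at 15000 nM (range 4000 nM to 45000 nM), an estimated step of a 1.0-fold higher number from compound 3 to compound 4 (0.01 log units; within the scatter).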

Compound 4, solubility: 32000 nM
The estimate for compound 4 lay 2.1-fold (0.33 log units) below the measured number, within the range that was stated.
By their numbers in this assay, from the lowest: compound 2; then compound 3; then compounds 1 and 4 (each within the scatter of the next).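

In this assay, naphthalen-1-yl on this aromatic carbon gives a 2.2-fold higher number from compound 3 to compound 4 (0.34 log units; beyond the scatter) and a 7.6-fold higher number from compound 2 to compound 4 (0.88 log units; beyond the scatter), while replacing 4-(tert-butyl)phenyl with it gives no change at the digits printed from compound 1 to compound 4 (within the scatter). Among the compounds shown here, the top of the set is therefore not tied to 4-(tert-butyl)phenyl: both directly attached aryl groups, in compound 1 and compound 4, stand above the phenoxy of compound 3 and the benzyl of compound 2, and no compound here goes against this. No measured evidence accounts for this order.

Open, going by these compounds, is whether directly attached 4-fluorophenyl would match compound 1 and compound 4. Also open, on these data alone, is how a non-aryl group, such as morpholine or a carboxylic acid, would read at this carbon.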